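Bromo to chloro on two cores

A few compounds are considered here, and "the series" means these few. Any claim that something is new, unique, unknown or untested is made for them only; others in the source may bear on it.

Measured compounds:
compound 1, `COC(=O)[C@@]1(C)CCC=C2[C@@H]1CC[C@@H](C)[C@]2(C)Cc1c[nH]c2c(Br)cccc12`: 22000 nM
compound 2, `COC(=O)[C@@]1(C)CCC=C2[C@@H]1CC[C@@H](C)[C@]2(C)Cc1c[nH]c2c(Cl)cccc12`: 22000 nM
compound 3, `COC(=O)[C@@]1(C)CC[C@@H]2C3=C1CC[C@@H](C)[C@]3(C)Cc1c2[nH]c2c(Br)cccc12`: 35000 nM

Within the data shown here, in a functional assay on A549 cells (Homo sapiens) for inhibition, read by sulforhodamine B assay, with a stated time of 48 h (on this read-out higher numbers stand for weaker inhibition of growth and lower numbers for stronger inhibition of growth), compound 1 and compound 2 give numbers within the scatter of each other; the step of no change at the digits printed from compound 1 to compound 2 (within the scatter) is the one measured example of the change (chloro in place of bromo on an aromatic carbon). The difference between the core of compound 1 and the core of compound 3 is not broken down here. Compound 3 stands nearest to compound 1 and furthest from compound 2, both within the scatter.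

Compound 4, `COC(=O)[C@@]1(C)CC[C@@H]2C3=C1CC[C@@H](C)[C@]3(C)Cc1c2[nH]c2c(Cl)cccc12`, is not yet measured. It relates to compound 3 through (chloro in place of bromo on an aromatic carbon), the same kind of change as that from compound 1 to compound 2, but on a six-membered aromatic ring that is part of a fused or bridged system of five rings rather than two. Because no change at the digits printed from compound 1 to compound 2 (within the scatter) showed no change, the step of no change at the digits printed from compound 3 to compound 4 (within the scatter) is expected to be of the same size. Compound 4 is therefore estimated at 35000 nM, with a range from 17000 nM to 70000 nM.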

Compound 4, concentration for 50% growth inhibition: 21000 nM
For compound 4 the middle estimate is 1.7-fold (0.22 log units) above the measured one; low and high end bracket the measured number.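

In this assay, chloro in place of bromo on the core of compound 3 gives a 1.7-fold lower number from compound 3 to compound 4 (0.22 log units; within the scatter), so on this core too the exchange stays inside the scatter. This does not show that other changes would carry between these cores, and two pairs cannot set a rule for a further core or explain why the bromo and chloro compounds read alike. For this single exchange, at this one place on the aromatic ring, the result does carry from the core of compound 1 to the core of compound 3: the same change on two cores in this assay, no change at the digits printed (within the scatter) from compound 1 to compound 2 and a 1.7-fold lower number (0.22 log units; within the scatter) from compound 3 to compound 4, 1.7-fold (0.22 log units) apart, within the scatter of two such steps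

The compounds shown leave open what a group other than a halogen, such as an amine, a methoxy or a nitrile, would do on this aromatic carbon, and what a plain hydrogen there would give. The methyl ester also stands unchanged in all four compounds, so a carboxylic acid or an amide in its place remains an open question.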